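Removing the second chloro from the benzyl group

This account rests on a few compounds, and the source may have more. Where it says the series, first, only, none or still open, it means among the compounds named here.

Among the compounds with values here, compound 1 `O=S(=O)(NCCCNCc1ccc(Cl)c(Cl)c1)c1cc(C(F)(F)F)cc(C(F)(F)F)c1` gives 2800 nM in a functional assay on ASPC1 cells (Homo sapiens) for inhibition, read by MTT assay, with a stated time of 72 h (on this read-out higher numbers stand for weaker inhibition of growth and lower numbers for stronger inhibition of growth), the lowest of the two numbers measured so far. Compound 2 `O=S(=O)(NCCCNCc1ccc(Cl)c(C(F)(F)F)c1)c1cc(C(F)(F)F)cc(C(F)(F)F)c1` gives 9600 nM in this assay. Within the data shown here, the single step between measured compounds, a 3.4-fold higher number from compound 1 to compound 2 (0.54 log units; beyond the scatter), exchanges chloro for trifluoromethyl on an aromatic carbon of the benzyl group and raises the number modestly.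

Compound 3 `O=S(=O)(NCCCNCc1cccc(Cl)c1)c1cc(C(F)(F)F)cc(C(F)(F)F)c1` has not yet been measured in this assay. Compared with compound 1, the change to compound 3 is hydrogen in place of chloro on an aromatic carbon. Among the measured compounds shown here, the step of a 3.4-fold higher number from compound 1 to compound 2 (0.54 log units; beyond the scatter) touches the same aromatic carbon and shows that the group there matters, but it puts a larger group in place of chloro, whereas compound 3 removes the chloro entirely; no measured step shows what removing a substituent from this ring does. The expectation is therefore a rise in the number from compound 1 to compound 3 of roughly the size seen with compound 2, with wide uncertainty, expressed as a 2.0-fold higher number from compound 1 to compound 3 (0.29 log units; within the scatter). Compound 3 is estimated at 5500 nM in this assay, with a range from 2000 nM to 15000 nM.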

Compound 3, concentration for 50% growth inhibition: 5900 nM
Estimate against measurement, compound 3: 1.1-fold (0.03 log units) below; low and high end bracket the measured number.
By their numbers in this assay, from the lowest: compound 1; then compounds 3 and 2 (each within the scatter of the next).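

In this assay, within the data shown here, the chloro para to a large group proves to count for something on its own: a 2.1-fold higher number from compound 1 to compound 3 (0.32 log units; beyond the scatter), a modest step beyond the scatter, and the first reading of what losing a substituent from this ring does, where the earlier step only exchanged one group for another. The 3-chlorophenyl of compound 3 and the 4-chloro-3-(trifluoromethyl)phenyl of compound 2 cannot be told apart, as a 1.6-fold lower number from compound 2 to compound 3 (0.21 log units; within the scatter) lies within the scatter, so of these three compounds only compound 1, with its 3,4-dichlorobenzyl group, stands clear of the others, with the lowest number. No measurement at hand says why the chloro at this carbon makes a difference.

Still open, on these data alone, is whether another group on the same carbon, such as fluoro, bromo or methoxy, would match chloro there, and whether a 4-chlorobenzyl or a plain benzyl group would follow the same direction. The three compounds also share one propyl chain and one sulfonamide, so they say nothing about how this ring behaves with a longer chain.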